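A few compounds are considered here, and "the series" means these few. Any claim that something is new, unique, unknown or untested is made for them only; others in the source may bear on it.

Of the compounds shown here, three have so far been measured in an assay on isolated protein for inhibition of DNA topoisomerase 1 (Homo sapiens), with a stated time of 30 min, tested at 20 uM; a lower number here means a weaker effect, a higher number a stronger effect of the compound at the concentration tested. Compound 1, `CN(C)c1ccc2nc(-c3cccc4ccccc34)[nH]c(=O)c2c1`, gives 2.4%. Compound 2, `Cc1cccc(-c2nc3ccc(C)cc3c(=O)[nH]2)c1`, gives 12.7%, and compound 3, `COc1cccc(-c2nc3ccc(C)cc3c(=O)[nH]2)c1`, gives 0%. For the measured compounds named here, compound 3 thus stands at the bottom of the three numbers: its value and that of compound 1 lie within the usual scatter of each other, whereas compound 2 sits higher by an amount beyond the scatter, as the only one-place step in the set shows: a number 12.7 percentage points lower from compound 2 to compound 3 (beyond the scatter), a modest change.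

Compound 4, `Cc1ccc2nc(-c3cccc(OC(F)(F)F)c3)[nH]c(=O)c2c1`, has not yet been measured. It differs from compound 3 in a single place: trifluoromethyl in place of methyl on an oxygen on an aromatic ring. Going by the values given here, no measured step covers this exchange; the one step that is known, methyl to methoxy, swaps a different group at the same place and was modest in size. A step of similar or smaller size, with no clear direction, is therefore expected in this assay. Compound 4 is expected to give about 3%, within a range from 0% to 14%. This corresponds to an expected step of a number 3 percentage points higher from compound 3 to compound 4 (within the scatter).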

Compound 4, a percentage reported as inhibition, at one concentration (the size of the read-out at that concentration, not a potency): 0%
Beside the measured number, compound 4's estimate is 3 percentage points above it; measured number inside the range.
By their numbers in this assay, from the lowest: compounds 3, 4 and 1 (each within the scatter of the next); then compound 2.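

In this assay, exchanging the methyl on the oxygen for trifluoromethyl gives no change at the digits printed from compound 3 to compound 4 (within the scatter), so methoxy and trifluoromethoxy cannot be told apart at this place, even though the new group is larger by three fluorine atoms. Set against the methyl group of compound 2, trifluoromethoxy gives a number 12.7 percentage points lower from compound 2 to compound 4 (beyond the scatter), so among these three compounds both oxygen-linked groups fall short of the plain methyl group. No measurement at hand explains this result.

As far as these compounds go, it remains open whether the number would hold or rise with another group in place of that methyl, such as an ethyl group, a chlorine atom or an amine. From the compounds shown here alone, it is also open whether a longer chain on the oxygen, such as ethoxy, would read any differently from methoxy.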